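Phenyl in place of 5-hydroxypentyl: what to expect

This account rests on a few compounds, and the source may have more. Where it says the series, first, only, none or still open, it means among the compounds named here.

Compound 1, `COc1ccc(CNc2nc([SeH])nc3ccccc23)cc1`: in a functional assay on HT-29 cells (Homo sapiens) for cytotoxicity, read by MTT assay, with a stated time of 72 h (a higher number here means a weaker inhibitor of growth, a lower number a stronger inhibitor of growth), compound 1 gives > 100000 nM, a limit of the assay.
Compound 2, `CSc1nc(NCCCCCO)c2ccccc2n1`: in this assay compound 2 gives > 100000 nM, again a limit.
Compound 3, `CSc1nc(NCCCc2ccccc2)c2ccccc2n1`: in this assay compound 3 gives 89600 nM.

Compound 2 therefore sits at the limit of > 100000 nM in this assay, at which 2 of the 3 values shown sit, so only a limit and no number is known for it. Compound 4, `CSc1nc(Nc2ccccc2)c2ccccc2n1`, differs from compound 2 by phenyl in place of 5-hydroxypentyl on a nitrogen on an aromatic ring. Among the measured compounds shown here, the one measured step that resembles it is an at least 1.1-fold lower number from compound 2 to compound 3 (0.04 log units; that floor lies within the scatter), which also brings phenyl in where part of a chain leaves and stays within the scatter. For the measured compounds named here, compound 4 removes the whole chain and places phenyl straight on the nitrogen, a change no measured pair covers. For compound 4 a step within the scatter is expected, an at least 1.2-fold lower number from compound 2 to compound 4 (0.09 log units; that floor lies within the scatter). The estimate for compound 4 is 80000 nM, between 20000 nM and 300000 nM, with a real chance that this assay again reports only a limit.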

Compound 4, concentration for total growth inhibition: > 100000 nM
Compound 4: only a limit was reported (the forecaster's own chance of this, stated with the estimate: 55%); at least 1.2-fold (0.09 log units) between middle value and limit.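

Among the compounds shown here, compound 2 and compound 4 both sit at a limit rather than a number, and no step between them can be read: the limit of > 100000 nM in this assay, at which 3 of the 4 values shown sit. On these data alone, whether phenyl in place of 5-hydroxypentyl on that nitrogen changes the result in this assay at all stays open.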